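This account rests on a few compounds, and the source may have more. Where it says the series, first, only, none or still open, it means among the compounds named here.

Compound 2, `O=C1CSC(N2N=C(c3ccc(Cl)cc3)CC2c2cccc3ccccc23)=N1`, was tested in a functional assay on HepG2 cells (Homo sapiens) for inhibition, read by CCK-8 assay, with a stated time of 48 h (on this read-out higher numbers stand for weaker inhibition and lower numbers for stronger inhibition), where compound 2 gives 16500 nM. Among the compounds with values here, the only other measured compound with this core is compound 1, `COc1ccc(C2=NN(C3=NC(c4ccccc4)CS3)C(c3cccc4ccccc34)C2)cc1`, which in this assay gives 8740 nM. The two numbers lie within the usual scatter of each other, so on present evidence compound 2 and compound 1 cannot be told apart.

Compound 3, `Clc1ccc(C2=NN(C3=NC(c4ccccc4)CS3)C(c3cccc4ccccc34)C2)cc1`, keeps the 4-chlorophenyl group of compound 2 and changes the group on the ring nitrogen: a group of 11 heavy atoms (9 carbon, 1 nitrogen, 1 sulfur; one five-membered non-aromatic ring with 2 hetero atoms, one six-membered aromatic ring of carbon only) in place of a group of 6 heavy atoms (3 carbon, 1 nitrogen, 1 oxygen, 1 sulfur; one five-membered non-aromatic ring with 2 hetero atoms), on an amine nitrogen in a ring. Within the data shown here, compound 1 carries this same entering group, and its number in this assay is its only guide.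

Among the measured compounds shown here, no pair of measured compounds differing in exactly this place exists, so the size of the step is open. The number of compound 1 in this assay, 8740 nM, suggests that a compound bearing the phenyl-substituted ring can sit at or somewhat below the number of compound 2, and the step from compound 2 to compound 3 is expected to be a 1.8-fold lower number from compound 2 to compound 3 (0.26 log units; within the scatter), toward stronger inhibition but modest. In this assay compound 3 is therefore estimated at 9000 nM, with a range from 3000 nM to 27000 nM.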

Compound 3, half-maximal inhibitory concentration: 18700 nM
Beside the measured number, compound 3's estimate is 2.1-fold (0.32 log units) below it, within the range that was stated.
By their numbers in this assay, from the lowest: compounds 1, 2 and 3 (each within the scatter of the next, the first and the last beyond it).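

In this assay, exchanging the group on the amine nitrogen in a ring gives a 1.1-fold higher number from compound 2 to compound 3 (0.05 log units; within the scatter), so this direct comparison at that position reveals no measurable difference between the two groups, even though the entering group adds a six-membered aromatic ring. Chloro in place of methoxy on an aromatic carbon, with the group on the ring nitrogen unchanged, gives a 2.1-fold higher number from compound 1 to compound 3 (0.33 log units; beyond the scatter), a modest step toward weaker inhibition and the only one of the two that reads beyond the scatter. Nothing available on these compounds gives a reason for either result.

Within the data shown here, only two groups have been compared on the ring nitrogen, so it remains open whether a group of another kind there, such as an open chain ending in an amine or a carboxylic acid, would shift the number. It is also unknown how a fluoro or a hydroxyl group would compare with chloro and methoxy on that aromatic carbon, and whether the methoxy group would give the same step with the other group on the ring nitrogen.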